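Series notes: removing the methyl from compound 1

The source may hold more compounds than are shown below. What is called first, only, known or untested is meant among the compounds shown, and "the series" means these compounds.

Compound 1, `Cc1ccc2[nH]c(=O)c(-c3nc4cc([N+](=O)[O-])ccc4[nH]3)cc2c1`, is measured in a functional assay on HepG2 cells (Homo sapiens) for cytotoxicity, read by MTT assay, with a stated time of 48 h (a lower number here means a stronger inhibitor, a higher number a weaker inhibitor), only as a limit: compound 1 gives > 100000 nM, which is a limit of the assay and not a number. Compound 3, `COc1ccc2[nH]c(=O)c(-c3nc4cc(C)c(C)cc4[nH]3)cc2c1`, also reaches a limit in this assay, with > 100000 nM. Within the data shown here, compound 2, `O=c1[nH]c2ccccc2cc1-c1nc2cc(F)ccc2[nH]1`, is the one member with a numeric reading, giving 15200 nM in this assay. Thus compound 1 sits with compound 3 at the weaker end of what is shown, and the only firm point for it is the limit of > 100000 nM in this assay, at which 2 of the 3 values shown sit. Among the measured compounds shown here, no pair of measured compounds differs in a single place, so no measured step is available.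

Compound 4, `O=c1[nH]c2ccccc2cc1-c1nc2cc([N+](=O)[O-])ccc2[nH]1`, is the unmeasured analogue; against compound 1 it shows (hydrogen in place of methyl on an aromatic carbon). With compound 1 known only as a limit and the two compounds differing by a single methyl, no more than a small shift is expected in this assay, in either direction, and most likely none beyond the scatter; the step from compound 1 to compound 4 is estimated as an at least 1.4-fold lower number from compound 1 to compound 4 (0.15 log units; that floor lies within the scatter). Compound 4 is expected to give 70000 nM in this assay, within 20000 nM to 200000 nM, with a fair chance that only a limit is again reported.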

Compound 4, half-maximal inhibitory concentration: > 100000 nM
Compound 4: a limit, no number (the forecaster's own chance of this, stated with the estimate: 55%); middle value at least 1.4-fold (0.15 log units) from the limit.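

Hydrogen in place of methyl on this aromatic carbon brings no reading into range in this assay: compound 1 and compound 4 are both limits, so the step between them cannot be read. The series now has its first readable single-place change, on the side that carries the nitro, with nitro in place of fluoro giving an at least 6.5-fold higher number from compound 2 to compound 4 (0.81 log units; beyond the scatter). Compound 4 itself is known only as a limit, and it joins the upper end of the set: the limit of > 100000 nM in this assay, at which 3 of the 4 values shown sit.

On these data alone, how far the nitro compounds lie past that limit stays open, so any effect of the methyl on them remains unknown. Also open, as far as these compounds go, is whether an amine or a carboxylic acid in place of nitro would return a numeric reading in this assay.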